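A few compounds are considered here, and "the series" means these few. Any claim that something is new, unique, unknown or untested is made for them only; others in the source may bear on it.

In a functional assay on the whole organism with Rattus norvegicus as the target (on this read-out higher numbers stand for an effect only at larger amounts of compound and lower numbers for an effect already at smaller amounts), compound 1 `CC1CCC(=NNc2ccccc2)c2ncc(C(=O)O)c(=O)n21` gives 1.2 umol/kg. Compound 2 `CC1CCC(=NNc2ccc(Br)cc2Cl)c2ncc(C(=O)O)c(=O)n21` reaches only the limit of the assay, > 100 umol/kg, which is not a number. Compound 3 `Cc1cccc(Cl)c1NN=C1CCC(C)n2c1ncc(C(=O)O)c2=O` likewise stands at the limit, > 100 umol/kg, so its place on the numbers shown is known only as that limit. Two of the three values sit at this edge (the limit of > 100 umol/kg in this assay, at which 2 of the 3 values shown sit). The measured steps that bear on the next change both start from compound 1: an at least 83-fold higher number from compound 1 to compound 2 (1.92 log units; beyond the scatter), and an at least 83-fold higher number from compound 1 to compound 3 (1.92 log units; beyond the scatter). Between compound 2 and compound 3 the two limits leave the step unreadable: a step that the two limits leave unreadable from compound 2 to compound 3.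

Compound 4 `CNN=C1CCC(C)n2c1ncc(C(=O)O)c2=O` is not yet measured. It differs from compound 3 in one place: methyl in place of 2-chloro-6-methylphenyl on an amine nitrogen. The measured steps show only that a 4-bromo-2-chlorophenyl or a 2-chloro-6-methylphenyl in place of phenyl moves the value far beyond the scatter; nothing measured here speaks to a methyl on that nitrogen, and the starting point is itself a limit, so the step cannot be read from the data. The estimate for compound 4 in this assay is therefore 30 umol/kg, with an expected range from 3 umol/kg to 100 umol/kg. This corresponds to an expected at least 3.3-fold lower number from compound 3 to compound 4 (0.52 log units; beyond the scatter), with a real chance that only a limit is reported again.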

Compound 4, dose for 50% inhibition: > 100 umol/kg
Compound 4 gave a limit, no number (the forecaster's own chance of this, stated with the estimate: 50%); at least 3.3-fold (0.52 log units) between middle value and limit.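

Putting methyl in place of phenyl on the amine nitrogen gives an at least 83-fold higher number from compound 1 to compound 4 (1.92 log units; beyond the scatter). Compounds 2 and 3 carry a phenyl ring with added atoms, while compound 4 has no ring on that nitrogen, yet compound 4 also reaches a limit of the assay rather than a number, so among the compounds shown, both adding to the phenyl and removing it lose the measurable effect. The steps among compounds 2, 3 and 4 cannot be read, because all three stand at the same limit: the limit of > 100 umol/kg in this assay, at which 3 of the 4 values shown sit.

Going by these compounds, how far each of these three compounds lies beyond that limit stays unknown, so they cannot be ranked against one another in this assay. Also open, on these data alone, is whether a benzyl, a cyclohexyl or a 4-fluorophenyl group on that nitrogen would restore a measurable effect, as the phenyl of compound 1 gives with 1.2 umol/kg.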